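The source may report more compounds than this note shows. Statements on the series, on what has been measured and on what is new or still open speak of the compounds shown alone.

Compound 1 `Cn1c(-c2cccnc2)nc2ccc(-c3ccccc3Cl)c(CN)c21` and compound 2 `Cn1cnc2ccc(-c3ccccc3CO)c(CN)c21` have both been tested in an in vitro ADME assay on microsomes from liver (Rattus norvegicus) for metabolic stability; a lower number here means that the compound disappears faster, a higher number that the compound lasts longer. Compound 1 gives 0.433 h, the smaller of the two numbers, while compound 2 gives 0.65 h; the gap between them lies within the scatter, so the two cannot be ranked. Compound 3 `Cc1nc2ccc(-c3ccccc3Cl)c(CN)c2n1C` differs from compound 1 in one place: methyl in place of pyridin-3-yl on an aromatic carbon. Among the measured compounds shown here, no measured pair shows what such a change does in this assay, so no step beyond the scatter is expected in either direction. The expected step is a 1.0-fold higher number from compound 1 to compound 3 (0.02 log units; within the scatter). For compound 3 the estimated half-life is 0.45 h, with a range from 0.2 h to 1 h.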

Compound 3, half-life: 0.117 h
Compound 3: the middle estimate sits 3.8-fold (0.59 log units) above what was measured; measured number outside the range, below it.
By their numbers in this assay, from the lowest: compound 3; then compounds 1 and 2 (each within the scatter of the next).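

Among the compounds shown here, at this aromatic carbon between two ring nitrogen atoms, the substituent matters in this assay: methyl in place of pyridin-3-yl gives a 3.7-fold lower number from compound 1 to compound 3 (0.57 log units; beyond the scatter) and is the first step here to lie beyond the scatter. With a six-membered aromatic ring replaced by a single carbon, the shorter half-life goes with methyl in this one pair. Nothing measured here explains the step. The compounds shown leave open whether phenyl, which lacks the ring nitrogen, would keep the number near compound 1. They also leave open where a longer chain such as propyl would fall.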